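A few compounds are considered here, and "the series" means these few. Any claim that something is new, unique, unknown or untested is made for them only; others in the source may bear on it.

In a functional assay on K562 cells (Homo sapiens) for inhibition, read by MTT assay, with a stated time of 48 h (on this read-out lower numbers stand for stronger inhibition and higher numbers for weaker inhibition), compound 1 (`O=C(Nc1nc2ccc(-c3cn([C@@H]4CN[C@H](C(=O)Nc5ccc(Cl)cc5Cl)C4)nn3)nc2s1)C1CC1`) gives 740 nM and compound 2 (`CC(=O)Nc1nc2ccc(-c3cn([C@@H]4CN[C@H](C(=O)Nc5ccc(F)c(F)c5)C4)nn3)nc2s1`) gives 63000 nM as the higher of the two numbers, a gap beyond the scatter. Relative to compound 2, compound 3 (`O=C(Nc1nc2ccc(-c3cn([C@@H]4CN[C@H](C(=O)Nc5ccc(F)c(F)c5)C4)nn3)nc2s1)C1CC1`) has cyclopropyl in place of methyl on a carbonyl carbon. Among the compounds with values here, compound 1 also holds cyclopropyl on that carbonyl carbon but differs from compound 2 elsewhere too, so no clean step for this change exists. In this assay a fall beyond the scatter is expected, estimated as a 7.0-fold lower number from compound 2 to compound 3 (0.85 log units; beyond the scatter) and smaller than that gap. Compound 3 is expected at 9000 nM with an estimated range of 2000 nM to 40000 nM on this read-out.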

Compound 3, half-maximal inhibitory concentration: 40700 nM
Estimate against measurement, compound 3: 4.5-fold (0.66 log units) below, and the stated range ends below it.
By their numbers in this assay, from the lowest: compound 1; then compounds 3 and 2 (each within the scatter of the next).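

In this assay cyclopropyl in place of methyl on a carbonyl carbon gives a 1.5-fold lower number from compound 2 to compound 3 (0.19 log units; within the scatter) and so leaves the number unresolved from that of the methyl compound. Within the data shown here, with cyclopropyl held at that carbonyl carbon, 3,4-difluorophenyl in place of 2,4-dichlorophenyl on an amide-type nitrogen gives a 55-fold higher number from compound 1 to compound 3 (1.74 log units; beyond the scatter) as the one large step here. No supporting measurement bears on either step.

Open, on these data alone, is whether a longer chain or an amine on that carbonyl carbon would shift the number. Also open, as far as these compounds go, is how 2,4-dichlorophenyl reads with methyl on that carbon.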